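Para substituent swaps on the cinnamamide series

A few compounds are considered here, and "the series" means these few. Any claim that something is new, unique, unknown or untested is made for them only; others in the source may bear on it.

Measured compounds:
- Compound 1 `COc1ccc(C(=O)c2cc(OC)c(OC)c(OC)c2)cc1NC(=O)/C=C/c1cc(OC)c(OC)c(OC)c1`, 3100 nM in a functional assay on HT-29 cells (Homo sapiens) for cytotoxicity, read by MTT assay, with a stated time of 72 h; on this read-out higher numbers stand for weaker inhibition and lower numbers for stronger inhibition
- Compound 2 `COc1ccc(/C=C/C(=O)Nc2cc(C(=O)c3cc(OC)c(OC)c(OC)c3)ccc2OC)cc1`, 5010 nM
- Compound 3 `COc1ccc(C(=O)c2cc(OC)c(OC)c(OC)c2)cc1NC(=O)/C=C/c1ccc(F)cc1`, 1800 nM

Compound 2 gives the highest number of the three; one of its two steps is a 1.6-fold higher number from compound 1 to compound 2 (0.21 log units; within the scatter), whereas the other is a 2.8-fold lower number from compound 2 to compound 3 (0.44 log units; beyond the scatter). Compound 4 `COc1ccc(C(=O)c2cc(OC)c(OC)c(OC)c2)cc1NC(=O)/C=C/c1ccc([N+](=O)[O-])cc1` is not yet measured. Its change from compound 2 is nitro in place of methoxy on an aromatic carbon.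

The step that bears most directly on this is the swap of the same methoxy for fluoro, a 2.8-fold lower number from compound 2 to compound 3 (0.44 log units; beyond the scatter), a modest move to a lower number. The steps involving compound 1 are both within the scatter and say little about the aromatic carbon concerned. Within the data shown here, only one step informs the exchange, so the expectation is tentative: a step of similar size and direction, toward a lower number, is expected, a 2.0-fold lower number from compound 2 to compound 4 (0.30 log units; within the scatter).

Compound 4 is therefore estimated at 2500 nM, with a range from 1000 nM to 6300 nM.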

Compound 4, half-maximal inhibitory concentration: 5100 nM
Estimate against measurement, compound 4: 2.0-fold (0.31 log units) below, and the stated range covers the measured number.
By their numbers in this assay, from the lowest: compounds 3, 1, 2 and 4 (each within the scatter of the next, the first and the last beyond it).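

On the aromatic carbon para to a large group, in this assay, exchanging methoxy for nitro leaves the number unchanged (a 1.0-fold higher number from compound 2 to compound 4 (0.01 log units; within the scatter)), so the lower number seen with fluoro does not extend to every replacement of methoxy. Fluoro also separates from nitro (a 2.8-fold higher number from compound 3 to compound 4 (0.45 log units; beyond the scatter)), whereas 4-nitrophenyl and 3,4,5-trimethoxyphenyl cannot be told apart (a 1.6-fold higher number from compound 1 to compound 4 (0.22 log units; within the scatter)). No measurement at hand accounts for the difference between fluoro and nitro.

On these data alone, only compound 3 carries the lower number, so whether it is particular to fluoro remains open. Chloro or an amine on the same aromatic carbon would test this.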